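The source may hold more compounds than are shown below. What is called first, only, known or untested is meant among the compounds shown, and "the series" means these compounds.

Measured in a functional assay (trachea) for inhibition, with Cavia porcellus as the target; a higher number here means a weaker inhibitor, a lower number a stronger inhibitor:
- compound 1 `CC1(C)c2ccc([N+](=O)[O-])cc2[C@@H](N2CCCC2=O)[C@@H]1O`: 2800 nM
- compound 2 `CC1(C)c2ccc([N+](=O)[O-])cc2[C@@H](N2CCCCC2=O)[C@H]1O`: 350 nM
- compound 3 `CC1(C)c2ccc(C#N)cc2[C@@H](N2CCCCC2=O)[C@@H]1O`: 270 nM

In this assay, compound 3 gives 270 nM. This lies within the scatter of compound 2 at 350 nM and well below compound 1 at 2800 nM, so compound 3 stands in the better part of this small set.

Compound 4 `CCc1ccc2c(c1)[C@@H](N1CCCCC1=O)[C@H](O)C2(C)C` is compound 3 with ethyl in place of cyano on an aromatic carbon. The change removes the triple bond and the hydrogen-bond acceptor counted for cyano. Among the compounds with values here, no pair of measured compounds differs in one place only, and none carries ethyl, so the data offer no direct guide to this change. On judgement alone, a moderate rise in the number in this assay is expected, beyond the scatter, meaning a weaker inhibitor.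

The expected change is a 3.3-fold higher number from compound 3 to compound 4 (0.52 log units; beyond the scatter). For compound 4 the estimated value is 900 nM, with an expected range of 250 nM to 3500 nM.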

Compound 4, half-maximal inhibitory concentration: 2780 nM
Estimate against measurement, compound 4: 3.1-fold (0.49 log units) below; low and high end bracket the measured number.
By their numbers in this assay, from the lowest: compounds 3 and 2 (each within the scatter of the next); then compounds 4 and 1 (each within the scatter of the next).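

In this assay, within the data shown here, the exchange of cyano for ethyl on this aromatic carbon gives a 10-fold higher number from compound 3 to compound 4 (1.01 log units; beyond the scatter) and is the only step in the set that changes a single place. It shows that the number at this position depends strongly on the group it carries: with the rest of compound 3 unchanged, the move to ethyl, which has no triple bond or counted hydrogen-bond acceptor, gives a much weaker inhibitor. Nothing at hand explains the size of this step.

The compounds shown leave open whether the triple bond, the acceptor or the ethyl group itself governs the step. Methoxy, acetyl or a plain hydrogen on the same carbon, with the rest of compound 3 unchanged, would be needed to tell these apart.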